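Acetamido in place of nitro on the benzyl sulfone

This account rests on a few compounds, and the source may have more. Where it says the series, first, only, none or still open, it means among the compounds named here.

Three compounds of the series have been run in an ADME assay on MRC5 cells (Homo sapiens) for cytotoxicity, read by MTT assay, with a stated time of 72 h; on this read-out lower numbers stand for stronger inhibition of growth and higher numbers for weaker inhibition of growth. Going by the values given here, compound 1 `COc1cc(OC)c(/C=C/S(=O)(=O)Cc2ccc(OC)c([N+](=O)[O-])c2)c(OC)c1` is the only member with a number: in this assay compound 1 gives 2910 nM. Compound 2 `COc1cc(/C=C/S(=O)(=O)Cc2ccc(OC)c([N+](=O)[O-])c2)cc(OC)c1` reaches only the limit of this assay, reported as > 30000 nM. Compound 3 `COc1cc(OC)c(NC(=O)CS(=O)(=O)Cc2ccc(OC)c([N+](=O)[O-])c2)c(OC)c1` likewise stops at a limit, reported as > 30000 nM. Most of the series therefore sits at the limit of > 30000 nM in this assay, at which 2 of the 3 values shown sit, and compound 1 is the one point from which a step can be reckoned.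

Compound 4 `COc1cc(OC)c(/C=C/S(=O)(=O)Cc2ccc(OC)c(NC(C)=O)c2)c(OC)c1` has not been measured. It differs from compound 1 in one place: acetamido in place of nitro on an aromatic carbon. No measured pair carries this change, so its size is not known from the shown compounds. In this assay a modest step toward weaker inhibition of growth is expected, possibly still within the scatter: a 2.1-fold higher number from compound 1 to compound 4 (0.31 log units; beyond the scatter). Compound 4 is accordingly estimated at 6000 nM, with a range from 1500 nM to 30000 nM, and a fair chance that only a limit is reported.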

Compound 4, concentration for 50% growth inhibition: 810 nM
The estimate for compound 4 lay 7.4-fold (0.87 log units) above the measured number, and the stated range ends above it.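

In this assay the exchange of nitro for acetamido brings a 3.6-fold lower number from compound 1 to compound 4 (0.56 log units; beyond the scatter) and so moves toward stronger inhibition of growth, the direction opposite to a loss. The nitro group is therefore not needed for this effect on these cells, and this aromatic carbon, ortho to a methoxy group, accepts acetamido with the effect kept. The earlier compounds shown here all carry nitro and could say nothing about this place.

On these data alone, a primary amine or a carboxylic acid on the same carbon would show whether the step belongs to acetamido itself or to the departure of nitro, and whether the exchange carries over to the cores of compound 2 and compound 3 stays open. Nothing measured among the compounds shown accounts for the step.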